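Trading the diethylamide for an oxetanyl amide

A few compounds are considered here, and "the series" means these few. Any claim that something is new, unique, unknown or untested is made for them only; others in the source may bear on it.

In a functional assay on MIA PaCa-2 cells (Homo sapiens) for inhibition, read by MTT assay, with a stated time of 3 days (a lower number here means a stronger inhibitor, a higher number a weaker inhibitor), compound 3 `CCN(CC)C(=O)[C@@H]1CCCN(S(=O)(=O)c2ccc(S(=O)(=O)N(CC)CC)cc2)C1` gives 700 nM, the second highest of the three numbers recorded. Its closest neighbour is compound 1 `CCN(CC)S(=O)(=O)c1ccc(S(=O)(=O)N2CCC[C@@H](C(=O)N[C@@H]3CCN(C(=O)OC(C)(C)C)C3)C2)cc1`, which in this assay gives 500 nM; the gap between the two is within the scatter of the method. Compound 2 `CCN(CC)S(=O)(=O)c1ccc(S(=O)(=O)N2CCC[C@@H](C(=O)NC3CN(C(=O)C4CC4)C3)C2)cc1` gives 3100 nM in this assay and stands furthest from compound 3.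

Compound 4 `CCN(CC)S(=O)(=O)c1ccc(S(=O)(=O)N2CCC[C@@H](C(=O)NC3COC3)C2)cc1` has not yet been measured. It differs from compound 3 in one place: (oxetan-3-yl)amino in place of diethylamino on a carbonyl carbon. Among the measured compounds shown here, two measured steps bear on this. The step of a 4.4-fold lower number from compound 2 to compound 3 (0.65 log units; beyond the scatter) shows that replacing a small cyclic amine on the carbonyl with diethylamino lowered the number; compound 4 reverses that kind of change, though the entering ring is smaller and carries no further group. The step of a 6.2-fold higher number from compound 1 to compound 2 (0.79 log units; beyond the scatter) shows that the nature of the small ring on the amide nitrogen itself moved the number by a modest amount. Taken together, a modest rise in this assay is expected for compound 4, in the direction of a weaker inhibitor, with wide uncertainty about its size. Compound 4 is therefore estimated at 1500 nM, with a range from 500 nM to 5000 nM, which would mean a step of a 2.1-fold higher number from compound 3 to compound 4 (0.33 log units; beyond the scatter).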

Compound 4, half-maximal inhibitory concentration: 900 nM
Estimate against measurement, compound 4: 1.7-fold (0.22 log units) above; the range from low to high includes it.
By their numbers in this assay, from the lowest: compounds 1, 3 and 4 (each within the scatter of the next); then compound 2.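

In this assay, the step of a 1.3-fold higher number from compound 3 to compound 4 (0.11 log units; within the scatter) shows that (oxetan-3-yl)amino can stand on this carbonyl carbon in place of diethylamino with no difference the method can resolve, although the entering group brings a four-membered ring, a hydrogen-bond donor and a hydrogen-bond acceptor that diethylamino lacks. The steps of a 3.4-fold lower number from compound 2 to compound 4 (0.54 log units; beyond the scatter) and a 1.8-fold higher number from compound 1 to compound 4 (0.26 log units; within the scatter) show that a ring on the amide nitrogen does not by itself go with a higher number: among these four compounds only compound 2, with its 1-(cyclopropylcarbonyl)azetidin-3-yl group, stands apart. No measurement is available that could explain why this exchange leaves the number within the scatter, or why compound 2 stands apart.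

The compounds shown leave open what the ring oxygen contributes, which a cyclobutyl group on the same amide nitrogen would address, and what the amide hydrogen contributes, which an N-methyl-N-(oxetan-3-yl) amide would address. They also leave open whether the cyclopropylcarbonyl group is what separates compound 2 from the others, a question for an azetidin-3-yl group carrying a free amine.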